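This account rests on a few compounds, and the source may have more. Where it says the series, first, only, none or still open, it means among the compounds named here.

In a functional assay on A-375 cells (Homo sapiens) for antiproliferative activity (a lower number here means a stronger inhibitor, a higher number a weaker inhibitor), compound 1 `O=C(Nc1ccc(-c2cscn2)cc1)C1CCN(Cc2ccc(F)c(F)c2)C1` gives 10000 nM, while compound 3 `O=C(Nc1ccc(-c2cscn2)cc1)C1CCCN(Cc2cc(F)cc(F)c2)C1` gives 1360 nM, the lower of the two numbers and a gap beyond the scatter. Compound 2 `O=C(Nc1ccc(-c2cscn2)cc1)C1CCCN(S(=O)(=O)c2ccc(F)c(F)c2)C1` is recorded only as a limit, > 20000 nM. Compound 3 therefore stands as the strongest inhibitor of the set so far. Compound 4 `O=C(Nc1ccc(-c2cscn2)cc1)C1CCCN(Cc2cccnc2)C1` awaits measurement. It differs from compound 3 as follows: pyridin-3-yl in place of 3,5-difluorophenyl on a saturated chain carbon bound to an amine nitrogen in a ring, with pyridin-3-yl in place of 3,5-difluorophenyl on a saturated chain carbon bound to an amine nitrogen in a ring. Among the measured compounds shown here, no measured pair shows this change directly. The expected step of a 2.9-fold higher number from compound 3 to compound 4 (0.47 log units; beyond the scatter) in this assay is a moderate rise in the number, beyond the scatter. For compound 4 the estimated value is 4000 nM, within an expected range of 1500 nM to 15000 nM.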

Compound 4, half-maximal inhibitory concentration: > 20000 nM
Compound 4: only a limit was reported; the forecaster's own chance of this, stated with the estimate: 15%; at least 5.0-fold (0.69 log units) between middle value and limit.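

In this assay, replacing 3,5-difluorophenyl with pyridin-3-yl on a saturated chain carbon bound to an amine nitrogen in a ring gives an at least 14-fold higher number from compound 3 to compound 4 (1.16 log units; beyond the scatter). Among the compounds shown here, this is the first step in the set that changes one place only, and it shows that activity at this position depends strongly on the aromatic ring it carries. Compound 4 is recorded only as a limit, so the step gives a minimum size: the limit of > 20000 nM in this assay, at which 2 of the 4 values shown sit.

The compounds shown leave open whether the ring nitrogen or the loss of both fluorines accounts for the step. An unsubstituted phenyl would separate the two.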